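The compounds below may be only part of what the source reports. "The series", "measured", "known", "first", "only" and "open" are said of these compounds alone.

Measured compounds:
compound 1, `C#CCN1CCC(OC(=O)Nc2ccc(C(C)C)cc2)CC1`, gives > 100000 nM
compound 2, `C#CCN1CCCC(COC(=O)Nc2ccc(C(C)C)cc2)C1`, gives > 100000 nM
compound 3, `CC(C)c1ccc(NC(=O)OC2CCN(Cc3ccccc3)CC2)cc1`, gives > 100000 nM

In an assay on BTI-TN-5B1-4 cells for inhibition of Amine oxidase [flavin-containing] A (Homo sapiens), read by fluorescence and Amplex Red, using microsomes, with a stated time of 15 min (on this read-out higher numbers stand for weaker inhibition and lower numbers for stronger inhibition), compound 1 gives > 100000 nM, which is a limit of the assay rather than a number. Compound 2 gives > 100000 nM, also a limit. Compound 3 gives > 100000 nM, again a limit. All three values sit at the limit of > 100000 nM in this assay, at which 3 of the 3 values shown sit. Compound 3 arises from compound 1 by phenyl in place of ethynyl on a saturated chain carbon bound to an amine nitrogen in a ring; the size of that step, a step that the two limits leave unreadable from compound 1 to compound 3, cannot be read because the limit of > 100000 nM in this assay, at which 3 of the 3 values shown sit, holds both values.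

Compound 4, `CC(C)c1ccc(NC(=O)OCC2CCCN(Cc3ccccc3)C2)cc1`, has not yet been measured. It differs from compound 2 by phenyl in place of ethynyl on a saturated chain carbon bound to an amine nitrogen in a ring, the same change. How the core of compound 2 differs from that of compound 1 is not broken down here. Compound 4 is expected at 150000 nM, from 50000 nM to 1000000 nM. This rests on compound 3, which gives > 100000 nM after the same change. The step this estimate means, a step that the limit leaves unreadable from compound 2 to compound 4, is expected to sit beside a step that the two limits leave unreadable from compound 1 to compound 3.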

Compound 4, half-maximal inhibitory concentration: > 100000 nM
Compound 4: a limit, no number; the forecaster's own chance of this, stated with the estimate: 85%; the middle value is on the limit's open side.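

Compound 4 gives > 100000 nM in this assay, a limit and not a number, so no new step can be read between compound 2 and compound 4: the limit of > 100000 nM in this assay, at which 4 of the 4 values shown sit.

The compounds shown leave open how strongly any of them inhibits, and whether phenyl in place of ethynyl changes that at all.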